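A few compounds are considered here, and "the series" means these few. Any claim that something is new, unique, unknown or untested is made for them only; others in the source may bear on it.

Compound 1, `O=C1O[C@@H](CO)CN1c1ccc(-n2cc(-c3ccccn3)cn2)c(F)c1`: > 400 ug/mL
Compound 2, `O=C1O[C@@H](CN2CCC(O)CC2)CN1c1ccc(-n2cc(-c3ccccn3)cn2)c(F)c1`: > 400 ug/mL
Compound 3, `O=C1O[C@@H](Cn2ccnn2)CN1c1ccc(-n2cc(-c3ccccn3)cn2)c(F)c1`: 225 ug/mL

In an ADME assay on HEK293-A cells (Homo sapiens) for cytotoxicity, read by MTT assay, with a stated time of 48 h (a lower number here means a stronger inhibitor, a higher number a weaker inhibitor), compound 1 gives > 400 ug/mL, which is a limit of the assay rather than a number. Compound 2 likewise gives > 400 ug/mL, again a limit. Going by the values given here, compound 3 gives 225 ug/mL, the only actual number among the three; the other two values sit at the limit of > 400 ug/mL in this assay, at which 2 of the 3 values shown sit. The step that the two limits leave unreadable from compound 1 to compound 2 cannot be read. The steps of an at least 1.7-fold lower number from compound 1 to compound 3 (0.24 log units; that floor lies within the scatter) and an at least 1.7-fold lower number from compound 2 to compound 3 (0.24 log units; that floor lies within the scatter) give only floors that lie within the scatter, so compound 3 cannot be called weaker or stronger than the other two.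

Compound 4, `O=C(NC[C@H]1CN(c2ccc(-n3cc(-c4ccccn4)cn3)c(F)c2)C(=O)O1)C(F)F`, differs from compound 3 by ((difluoromethyl)carbonyl)amino in place of 1H-1,2,3-triazol-1-yl on a saturated chain carbon bound to a saturated ring carbon. Among the compounds with values here, no measured step introduces this group; the only readable steps at that place remove a triazole, and both are too small to show a direction. For compound 4 a change of about a 1.3-fold higher number from compound 3 to compound 4 (0.12 log units; within the scatter) is therefore expected, within scatter. Compound 4 is expected to give 300 ug/mL in this assay, with a likely range from 150 ug/mL to 450 ug/mL.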

Compound 4, half-maximal inhibitory concentration: 167 ug/mL
The estimate for compound 4 lay 1.8-fold (0.25 log units) above the measured number; low and high end bracket the measured number.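

In this assay, going by these compounds alone, the ((difluoromethyl)carbonyl)amino group on a saturated chain carbon bound to a saturated ring carbon gives the first steps at this place that clear the scatter: an at least 2.3-fold lower number from compound 1 to compound 4 (0.37 log units; beyond the scatter), and an at least 2.3-fold lower number from compound 2 to compound 4 (0.37 log units; beyond the scatter). Both are only floors, set by two values that are limits: the limit of > 400 ug/mL in this assay, at which 2 of the 4 values shown sit. The ring of compound 3 and the open group of compound 4 cannot be told apart here, despite their different make-up, with a 1.3-fold lower number from compound 3 to compound 4 (0.13 log units; within the scatter).

Going by these compounds, how far the true values of compound 1 and compound 2 lie past that limit stays open, and so does the full size of those two steps. Also open, on these data alone, is whether an acetylamino group without fluorine, or a plain amine, at this place would read like compound 4 or like compound 1.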